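The source may report more compounds than this note shows. Statements on the series, on what has been measured and on what is new or still open speak of the compounds shown alone.

The measured compounds:

Compound 1, `CCCc1nc2cc(-c3nc4cc(-c5nc6cc(-c7ccccc7)ccc6[nH]5)ccc4[nH]3)ccc2[nH]1`: 60 nM
Compound 2, `Clc1ccc(-c2ccc3[nH]c(-c4ccc5[nH]c(-c6ccc7[nH]cnc7c6)nc5c4)nc3c2)cc1`: 90 nM
Compound 3, `c1ccc2c(-c3ccc4[nH]c(-c5ccc6[nH]c(-c7ccc8[nH]cnc8c7)nc6c5)nc4c3)cccc2c1`: 2100 nM

In a functional assay on RPMI 8402 cells (Homo sapiens) for cytotoxicity (a lower number here means a stronger inhibitor, a higher number a weaker inhibitor), compound 3 stands at the highest of the three numbers. Its nearest neighbour is compound 2, and the step of a 23-fold higher number from compound 2 to compound 3 (1.37 log units; beyond the scatter) separates them; compound 1 lies further away still, with a lower number than compound 3 well beyond the scatter, though no single change links those two.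

Compound 4 is `c1ccc(-c2ccc3[nH]c(-c4ccc5[nH]c(-c6ccc7[nH]cnc7c6)nc5c4)nc3c2)cc1`. It differs from compound 3 in one place: phenyl in place of naphthalen-1-yl on an aromatic carbon. Among the compounds with values here, only one measured step bears directly on this change, and it is the one just named, a 23-fold higher number from compound 2 to compound 3 (1.37 log units; beyond the scatter), in which naphthalen-1-yl entered and the number rose sharply. Compound 4 walks that change back to a smaller ring, phenyl, so a large fall in the number is expected in this assay, bringing compound 4 close to where compound 2 stands at 90 nM. Whether the missing chlorine matters cannot be read from these compounds.

Compound 4 is therefore expected to give about 120 nM, within a range from 40 nM to 400 nM. The expected step of an 18-fold lower number from compound 3 to compound 4 (1.24 log units; beyond the scatter) is thus a large drop, roughly undoing the earlier rise.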

Compound 4, half-maximal inhibitory concentration: 90 nM
Estimate against measurement, compound 4: 1.3-fold (0.12 log units) above; low and high end bracket the measured number.
By their numbers in this assay, from the lowest: compounds 1, 2 and 4 (each within the scatter of the next); then compound 3.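

In this assay a 23-fold lower number from compound 3 to compound 4 (1.37 log units; beyond the scatter) shows that the high number of compound 3 goes with naphthalen-1-yl itself and not with the absence of chlorine, since the step back to phenyl, with one aromatic ring instead of two, recovers the full difference. The chlorine on the phenyl ring turns out not to be needed at this position: replacing it with hydrogen gives no change at the digits printed from compound 2 to compound 4 (within the scatter) in this comparison, so the two rings cannot be told apart here. Elsewhere on the core, hydrogen in place of propyl on an aromatic carbon gives a 1.5-fold higher number from compound 1 to compound 4 (0.18 log units; within the scatter) and so also leaves the number within the usual spread, which means that this position tolerates either a small chain or nothing in this cell test.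

Still open, on these data alone, is how a phenyl ring carrying an amine or a carboxylic acid would behave, and whether a chain longer than propyl would stay as well tolerated. Nothing measured in this set explains why naphthalen-1-yl raises the number so sharply.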